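This account rests on a few compounds, and the source may have more. Where it says the series, first, only, none or still open, it means among the compounds named here.

Compound 3 `O=C(Nc1cccc(-c2nc(-c3ccc(NC(=O)c4cccnc4)cc3Cl)no2)c1)Nc1ccc(NC(=O)C2CCCC2)c(C(F)(F)F)c1` gives the lowest number of the three measured in a functional assay on MDA-MB-231 cells (Homo sapiens) for antiproliferative activity, read by MTT assay, with a stated time of 72 h (on this read-out higher numbers stand for weaker inhibition and lower numbers for stronger inhibition), at 300 nM. Compound 1 `O=C(Nc1cccc(-c2nc(-c3ccc(NC(=O)c4cccnc4)cc3Cl)no2)c1)Nc1ccc(Cl)c(C(F)(F)F)c1` gives 1900 nM and compound 2 `O=C(Nc1cccc(-c2nc(-c3ccc(NC(=O)c4cccnc4)cc3Cl)no2)c1)Nc1cc(C(F)(F)F)cc(C(F)(F)F)c1` gives 1900 nM; the step of a 6.3-fold lower number from compound 1 to compound 3 (0.80 log units; beyond the scatter) is beyond the scatter, and compound 2 sits at the same value as compound 1. Compound 4 `NC(=O)Nc1ccc(NC(=O)Nc2cccc(-c3nc(-c4ccc(NC(=O)c5cccnc5)cc4Cl)no3)c2)cc1C(F)(F)F` differs from compound 3 by amino in place of cyclopentyl on a carbonyl carbon, that is, (cyclopentylcarbonyl)amino to ureido. Going by the values given here, no measured pair exchanges a substituent on this carbonyl carbon. The amide-type nitrogen and its carbonyl remain in compound 4, whereas the measured step of a 6.3-fold lower number from compound 1 to compound 3 (0.80 log units; beyond the scatter) removed or added the whole group, so a loss of that full size is not expected; for compound 4 a smaller upward step is expected, a 2.3-fold higher number from compound 3 to compound 4 (0.37 log units; beyond the scatter). Compound 4 is estimated at 700 nM, range 200 nM to 2500 nM.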

Compound 4, half-maximal inhibitory concentration: 3400 nM
Beside the measured number, compound 4's estimate is 4.9-fold (0.69 log units) below it; measured number outside the range, above it.
By their numbers in this assay, from the lowest: compound 3; then compounds 1, 2 and 4 (each within the scatter of the next).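

In this assay the substituent on the carbonyl carbon matters: with amino in place of cyclopentyl, an 11-fold higher number from compound 3 to compound 4 (1.05 log units; beyond the scatter) shows that keeping the amide-type nitrogen and carbonyl does not keep the lower number of compound 3. With ureido in place of chloro on an aromatic carbon, a 1.8-fold higher number from compound 1 to compound 4 (0.25 log units; within the scatter) leaves no separation, so at this place only (cyclopentylcarbonyl)amino stands apart from chloro. Nothing available explains this loss. On these data alone, whether the cyclopentyl ring is specifically required stays open. A methyl, cyclohexyl or phenyl group on this carbonyl carbon would test that.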